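Ring-carbon substituent in the acrylamide thiazolidine series

This account rests on a few compounds, and the source may have more. Where it says the series, first, only, none or still open, it means among the compounds named here.

Three members of the series have been measured in a functional assay on MV cells (Homo sapiens) for inhibition, read by sulforhodamine B assay; a lower number here means a stronger inhibitor, a higher number a weaker inhibitor. Compound 1 `C#CC(=O)N1C(c2ccc(C#N)cc2)SC[C@@H]1C(=O)OCC` carries a 4-cyanophenyl group on the saturated ring carbon of the core and gives 2400 nM. Compound 2 `C#CC(=O)N1C(CC(C)CC(C)(C)C)SC[C@@H]1C(=O)OCC` carries a branched chain there and gives 1100 nM. Compound 3 `C#CC(=O)N1C(CCCC)SC[C@@H]1C(=O)OCC` carries butyl at the same position and gives 400 nM, the lowest of the three numbers; the nearest is compound 2 and the furthest is compound 1. Going by the values given here, the only single-point step among the measured compounds is a 2.8-fold lower number from compound 2 to compound 3 (0.44 log units; beyond the scatter), with propyl in place of 1,3,3-trimethylbutyl on the saturated chain carbon bound to the saturated ring carbon.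

Compound 4 `C#CC(=O)N1C(c2ccccc2F)SC[C@@H]1C(=O)OCC` differs from compound 3 by 2-fluorophenyl in place of butyl on a saturated ring carbon. Among the compounds with values here, no measured step covers an aromatic ring entering at this position directly; the only guide is the pair compound 1 and compound 3, where the aryl-bearing compound 1 stands at 2400 nM while compound 3 stands at 400 nM. On that basis a move toward a higher number is expected for compound 4 in this assay, of a size near a 3.8-fold higher number from compound 3 to compound 4 (0.57 log units; beyond the scatter), though the 2-fluorophenyl group is not the 4-cyanophenyl group of compound 1 and the uncertainty is wide. The estimate for compound 4 is 1500 nM, within a range from 500 nM to 4500 nM.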

Compound 4, half-maximal inhibitory concentration: 1700 nM
The estimate for compound 4 lay 1.1-fold (0.05 log units) below the measured number; measured number inside the range.
By their numbers in this assay, from the lowest: compound 3; then compounds 2, 4 and 1 (each within the scatter of the next, the first and the last beyond it).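

In this assay, going by these compounds alone, the step from butyl to 2-fluorophenyl on the saturated ring carbon is a 4.3-fold higher number from compound 3 to compound 4 (0.63 log units; beyond the scatter), the first single-point step that brings an aromatic ring directly onto this position. Compound 3 keeps the lowest of the four numbers, with each of the other three beyond the scatter from it, so butyl remains the best-placed group measured at this carbon. Compound 4 stands within the scatter of both compound 1 and compound 2, so the 2-fluorophenyl group cannot be separated in this assay from either the 4-cyanophenyl group or the branched chain. Nothing on hand explains the size or direction of the step.

Still open, going by these compounds, is whether plain phenyl would stand with compound 4 or nearer compound 3, which would show how much of the step belongs to the ring and how much to its fluorine, and whether a straight chain longer than butyl, such as hexyl, would give a lower number than compound 3. On these data alone, all four compounds also carry the ethoxycarbonyl group unchanged, so the effect of a carboxylic acid in its place remains unknown.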